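Adding Bromo to the Naphthyl-Bearing Core of Compound 2

The source may hold more compounds than are shown below. What is called first, only, known or untested is meant among the compounds shown, and "the series" means these compounds.

Compound 2 `COc1ccc(C2CC(c3ccc4ccccc4c3)=NN2C2=NC(=O)/C(=C3\C(=O)Nc4ccccc43)S2)cc1` was tested in a functional assay on cells (Cancer cell lines, Homo sapiens) for cytotoxicity, read by sulforhodamine B assay, with a stated time of 48 h (on this read-out lower numbers stand for stronger inhibition of growth and higher numbers for weaker inhibition of growth), where it gives 1680 nM. Going by the values given here, of the two numbers measured so far, that is the highest. Among the compounds with values here, the only point of comparison is compound 1 `COc1ccc(C2CC(c3ccccc3)=NN2C2=NC(=O)/C(=C3\C(=O)Nc4ccc(Br)cc43)S2)cc1`, which in this assay gives 190 nM; compound 1 differs from compound 2 in two places at once, so the two values can only be set side by side and not traced to a single structural change. Compound 3 `COc1ccc(C2CC(c3ccc4ccccc4c3)=NN2C2=NC(=O)/C(=C3\C(=O)Nc4ccc(Br)cc43)S2)cc1` is the next step: relative to compound 2 it carries bromo in place of hydrogen on an aromatic carbon. Within the data shown here, no step of exactly this kind exists among the measured compounds. Compound 1, which carries the same bromo, shows the lower number, so a lower number for compound 3 than for compound 2 seems plausible, though the size of the shift is uncertain. Compound 3 is therefore expected to give 700 nM, with a likely range from 200 nM to 2500 nM. This amounts to an estimated step of a 2.4-fold lower number from compound 2 to compound 3 (0.38 log units; beyond the scatter), a moderate move toward stronger inhibition.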

Compound 3, concentration for 50% growth inhibition: 50 nM
Beside the measured number, compound 3's estimate is 14-fold (1.15 log units) above it, outside the stated range (below it).
By their numbers in this assay, from the lowest: compound 3; then compound 1; then compound 2.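

In this assay, going by these compounds alone, bromo in place of hydrogen on an aromatic carbon of the six-membered ring gives a 34-fold lower number from compound 2 to compound 3 (1.53 log units; beyond the scatter) and provides the first reading of this change on its own. The comparison of compound 1 with compound 2 could not give this reading, as those two differ in two places. With the bromo present, naphthalen-2-yl in place of phenyl gives a 3.8-fold lower number from compound 1 to compound 3 (0.58 log units; beyond the scatter) and so also lowers the number, though by less than the bromo does in the naphthyl series. Within the data shown here, nothing available explains why this one added atom moves the number so far.

Each change has been read against only one background, so the compounds shown leave open whether naphthalen-2-yl would lower the number without the bromo and whether the bromo would have as large an effect with phenyl. They also leave open whether the gain is particular to bromo or would also appear with another group on the same carbon, such as chloro, an amine or a carboxylic acid.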